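A few compounds are considered here, and "the series" means these few. Any claim that something is new, unique, unknown or untested is made for them only; others in the source may bear on it.

The measured compounds and their values:

Compound 1, `Cn1cnc(CN2CCN(c3cccc4[nH]c(-c5ccc(C(C)(C)C)cc5)nc34)CC2)c1`, gives 98 nM in an assay on isolated protein for displacement of a labelled ligand from Gonadotropin-releasing hormone receptor (Rattus norvegicus); on this read-out lower numbers stand for stronger inhibition and higher numbers for weaker inhibition.
Compound 2, `Cc1nc(C)c(CN2CCN(c3cccc4[nH]c(-c5ccc(C(C)(C)C)cc5)nc34)CC2)o1`, gives 740 nM in this assay.
Compound 3, `CCc1nc(C)c(CN2CCN(c3cccc4[nH]c(-c5ccc(C(C)(C)C)cc5)nc34)CC2)o1`, gives 320 nM in this assay.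

Compound 3 stands second highest of the three numbers: its nearest neighbour is compound 2, with a 2.3-fold lower number from compound 2 to compound 3 (0.36 log units; beyond the scatter), while compound 1 lies furthest away, with a 3.3-fold higher number from compound 1 to compound 3 (0.51 log units; beyond the scatter). Compound 4, `CCCn1c(CC)nc(C)c1CN1CCN(c2cccc3[nH]c(-c4ccc(C(C)(C)C)cc4)nc23)CC1`, differs from compound 3 by 2-ethyl-4-methyl-1-propyl-1H-imidazol-5-yl in place of 2-ethyl-4-methyl-1,3-oxazol-5-yl on a saturated chain carbon bound to an amine nitrogen in a ring.

Two of the measured steps bear on this change. The step of a 3.3-fold higher number from compound 1 to compound 3 (0.51 log units; beyond the scatter) shows that going from a 1-methyl-1H-imidazol-4-yl to a 2-ethyl-4-methyl-1,3-oxazol-5-yl raised the number, so the return to an imidazole ring in compound 4 points toward a lower number. The step of a 2.3-fold lower number from compound 2 to compound 3 (0.36 log units; beyond the scatter) shows that a larger alkyl group on the five-membered ring lowered the number, and compound 4 carries a propyl on the ring nitrogen in addition. A modest step downward in this assay is therefore expected, a 3.2-fold lower number from compound 3 to compound 4 (0.51 log units; beyond the scatter). Its size is expected to be roughly that of the measured step between compound 1 and compound 3 run backwards. Compound 4 is estimated at 100 nM, with a range from 30 nM to 330 nM.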

Compound 4, half-maximal inhibitory concentration: 120 nM
Estimate against measurement, compound 4: 1.2-fold (0.08 log units) below; the measured number falls inside the stated range.
By their numbers in this assay, from the lowest: compounds 1 and 4 (each within the scatter of the next); then compound 3; then compound 2.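

In this assay, the 2-ethyl-4-methyl-1-propyl-1H-imidazol-5-yl in place of the 2-ethyl-4-methyl-1,3-oxazol-5-yl gives a 2.7-fold lower number from compound 3 to compound 4 (0.43 log units; beyond the scatter) and in place of the 2,4-dimethyl-1,3-oxazol-5-yl gives a 6.2-fold lower number from compound 2 to compound 4 (0.79 log units; beyond the scatter), so among the compounds shown, both imidazole compounds have lower numbers than both oxazole compounds, and none goes against this. The position on a saturated chain carbon bound to an amine nitrogen in a ring also accepts the heavily substituted imidazole without a measurable loss, as the comparison with the 1-methyl-1H-imidazol-4-yl of the first compound gives a 1.2-fold higher number from compound 1 to compound 4 (0.09 log units; within the scatter). The compounds shown come with no separate measurement that explains these steps.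

From the compounds shown here alone, compound 4 differs from compound 3 in both the ring and the added propyl, so the share of each in the step remains unknown, and a 2-ethyl-4-methyl-1H-imidazol-5-yl carrying a hydrogen in place of the propyl would be needed to separate them. Also open, going by these compounds, is how the number would respond to a longer chain than propyl, or to a chain ending in an amine or a carboxylic acid, at that same place on the imidazole.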